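Methoxy in place of hydrogen on compound 1

The source may hold more compounds than are shown below. What is called first, only, known or untested is meant among the compounds shown, and "the series" means these compounds.

Measured in an ADME assay on HEK293 cells (Homo sapiens) for cytotoxicity, read by resazurin assay, with a stated time of 72 h; on this read-out higher numbers stand for lower toxicity in this test and lower numbers for higher toxicity in this test:
- compound 1 `CCc1cccc(CNC(=O)c2nc3cccc(COCc4ccc(C(=O)O)cc4)c3c(=O)[nH]2)c1`: > 40000 nM
- compound 2 `CCc1cccc(CNC(=O)c2nc3ccc(Br)c(COCc4ccc(C(=O)O)cc4)c3c(=O)[nH]2)c1`: > 20000 nM
- compound 3 `CCc1cccc(CNC(=O)c2nc3ccc(OC)c(COCc4ccc(C(=O)O)cc4)c3c(=O)[nH]2)c1`: > 20000 nM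

Compound 1 stands at a limit, > 40000 nM, and has no number. Compound 2 and compound 3 share a different limit: the limit of > 20000 nM in this assay, at which 2 of the 3 values shown sit.

Compound 4 `CCc1cccc(CNC(=O)c2nc3c(OC)ccc(COCc4ccc(C(=O)O)cc4)c3c(=O)[nH]2)c1` differs from compound 1 by one change: methoxy in place of hydrogen on an aromatic carbon. The new methoxy sits para to a ((4-carboxybenzyl)oxy)methyl group.

For the measured compounds named here, the closest precedent is a step that the two limits leave unreadable from compound 1 to compound 3, which makes the same kind of change at another place. The other evidence is a step that the two limits leave unreadable from compound 1 to compound 2. Neither gives a size, so no step beyond the scatter is expected in this assay, and no direction is expected either.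

The expected step is an at least 1.3-fold lower number from compound 1 to compound 4 (0.12 log units; that floor lies within the scatter). For compound 4 the estimated value is 30000 nM, with an expected range of 15000 nM to 60000 nM.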

Compound 4, half-maximal cytotoxic concentration: > 20000 nM
Compound 4 gave a limit, no number (the forecaster's own chance of this, stated with the estimate: 85%); the middle value lies beyond the limit too.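

No step can be read from compound 1 to compound 4: both values are limits of the assay, not numbers. The compounds shown leave open whether methoxy or bromo on the shared core changes the half-maximal cytotoxic concentration at all.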